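A few compounds are considered here, and "the series" means these few. Any claim that something is new, unique, unknown or untested is made for them only; others in the source may bear on it.

In an assay on CHO cells for displacement of a labelled ligand from adenosine receptor A1 (Homo sapiens), read by scintillation counting, with a stated time of 120 min, tested at 10 uM (a higher number here means more inhibition at the concentration tested (going by the name of the read-out), a lower number less inhibition), compound 2 `Nc1scc(CN2CCN(c3ccccc3F)CC2)c1C(=O)c1ccc(Cl)cc1` gives 4%, and compound 1 `Nc1scc(CN2CCN(c3ccc(Cl)c(C(F)(F)F)c3)CC2)c1C(=O)c1ccc(Cl)cc1` gives 0%, so the two measured numbers lie within the usual scatter of each other. Going by the values given here, the one measured step, a number 4 percentage points higher from compound 1 to compound 2 (within the scatter), exchanges the aryl group on the same ring nitrogen and stays within the scatter. Compound 3 `Nc1scc(CN2CCN(c3ccc(F)c(Cl)c3)CC2)c1C(=O)c1ccc(Cl)cc1` differs from compound 2 by 3-chloro-4-fluorophenyl in place of 2-fluorophenyl on an amine nitrogen in a ring. Since that earlier exchange at this position moved nothing beyond the scatter, compound 3 is expected to show a step of a number 1 percentage points lower from compound 2 to compound 3 (within the scatter) in this assay, no change beyond the scatter. Compound 3 is therefore estimated at 3%, between -7% and 13%.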

Compound 3, a percentage reported as inhibition, at one concentration (the size of the read-out at that concentration, not a potency): 0%
Compound 3: the middle estimate sits 3 percentage points above what was measured; the measured number falls inside the stated range.
By their numbers in this assay, from the lowest: compounds 1, 3 and 2 (each within the scatter of the next).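

In this assay the entry of 3-chloro-4-fluorophenyl on the amine nitrogen in the ring brings a number 4 percentage points lower from compound 2 to compound 3 (within the scatter) and also no change at the digits printed from compound 1 to compound 3 (within the scatter), so a third halogen-bearing phenyl group at this position again leaves the read-out within the scatter. Across these three phenyl groups, this position shows no difference that can be told from the scatter.

As far as these compounds go, whether a pyridine ring, a benzyl group or a carboxylic acid at this position would move the number stays open. Nothing given here explains these numbers.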